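Tert-butyl Ester Change Carried Over to a Second Compound

The source may report more compounds than this note shows. Statements on the series, on what has been measured and on what is new or still open speak of the compounds shown alone.

A set of compounds built on one shared core has been measured in an assay on isolated protein for inhibition of Voltage-dependent L-type calcium channel subunit alpha-1C (Cavia porcellus); a higher number here means a weaker inhibitor, a lower number a stronger inhibitor. Compound 1 `CCCOC(=O)C1=C(C)NC(C)=C(C(=O)OC)C1c1[nH]cnc1Cl` gives 437 nM. Compound 2 `COC(=O)C1=C(C)NC(C)=C(C(=O)OC(C)(C)C)C1c1[nH]cnc1Cl` gives 1860 nM in this assay. Compound 3 `CCCOC(=O)C1=C(C)NC(C)=C(C(=O)OCC)C1c1[nH]cnc1Cl` gives 407 nM in this assay. Compound 3 differs from compound 1 by methyl in place of hydrogen on a saturated chain carbon bound to an oxygen next to a carbonyl group, and the step between them is a 1.1-fold lower number from compound 1 to compound 3 (0.03 log units; within the scatter). The change from compound 1 to compound 2 is tert-butyl in place of propyl on an oxygen next to a carbonyl group, and that step was a 4.3-fold higher number from compound 1 to compound 2 (0.63 log units; beyond the scatter).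

Compound 4 `CCOC(=O)C1=C(C)NC(C)=C(C(=O)OC(C)(C)C)C1c1[nH]cnc1Cl` has not yet been measured. It differs from compound 3 by tert-butyl in place of propyl on an oxygen next to a carbonyl group, the same change as that between compound 1 and compound 2, made at the same place. Because the step of a 4.3-fold higher number from compound 1 to compound 2 (0.63 log units; beyond the scatter) was measured on a core whose only difference from compound 3 is methyl in place of hydrogen on a saturated chain carbon bound to an oxygen next to a carbonyl group, a difference that stayed within the scatter, compound 4 is expected to follow that step, giving a 4.3-fold higher number from compound 3 to compound 4 (0.63 log units; beyond the scatter). Compound 4 is therefore estimated at 1750 nM in this assay, with a range from 800 nM to 3800 nM.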

Compound 4, half-maximal inhibitory concentration: 1660 nM
Compound 4: the middle estimate sits 1.1-fold (0.02 log units) above what was measured; the measured number falls inside the stated range.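

In this assay, tert-butyl in place of propyl gave a 4.1-fold higher number from compound 3 to compound 4 (0.61 log units; beyond the scatter), which matches the step seen on the earlier core: the same change on two cores in this assay, a 4.3-fold higher number (0.63 log units; beyond the scatter) from compound 1 to compound 2 and a 4.1-fold higher number (0.61 log units; beyond the scatter) from compound 3 to compound 4, 1.0-fold (0.02 log units) apart, within the scatter of two such steps. Methyl in place of hydrogen on the saturated chain carbon bound to the oxygen gave a 1.1-fold lower number from compound 2 to compound 4 (0.05 log units; within the scatter), and this small step also agrees with its earlier counterpart: the same change on two cores in this assay, a 1.1-fold lower number (0.03 log units; within the scatter) from compound 1 to compound 3 and a 1.1-fold lower number (0.05 log units; within the scatter) from compound 2 to compound 4, 1.0-fold (0.02 log units) apart, within the scatter of two such steps. Across these four compounds, each change therefore carried from one core to the other with its size intact, but the cores differ only by that one small change, so this does not show that the tert-butyl step would hold on a core that differs more, nor does it explain why the step has this size.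

On these data alone, it remains open whether the same step would appear alongside a longer chain, or with an amine on the ester chain or a carboxylic acid in place of the ester. The compounds shown also leave open how the change behaves when the shared core is altered anywhere other than at these ester groups.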